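Removing the ortho bromine from a diaryl thiourea

The source may report more compounds than this note shows. Statements on the series, on what has been measured and on what is new or still open speak of the compounds shown alone.

Measured so far:
- compound 1 `COc1cccc(NC(=S)Nc2cccc(C(F)(F)F)c2)c1`: 26000 nM
- compound 2 `FC(F)(F)c1cccc(NC(=S)Nc2ccc(I)cc2)c1`: 10000 nM
- compound 3 `FC(F)(F)c1cccc(NC(=S)Nc2ccccc2Br)c1`: 36000 nM

All three compounds share a thiourea core carrying a trifluoromethylphenyl group, and all were tested in an ADME assay on MT4 cells (Homo sapiens) for cytotoxicity; on this read-out lower numbers stand for higher toxicity in this test and higher numbers for lower toxicity in this test. Compound 3 gives 36000 nM, the highest of the three numbers; compound 1 lies within the usual scatter of that value, while compound 2 gives a number beyond the scatter below it. Among the compounds with values here, the one directly comparable step is a 3.6-fold higher number from compound 2 to compound 3 (0.56 log units; beyond the scatter), which swaps one halogen-bearing ring for another.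

Compound 4 `FC(F)(F)c1cccc(NC(=S)Nc2ccccc2)c1` differs from compound 3 by hydrogen in place of bromo on an aromatic carbon. Read one bond further out, the change is 2-bromophenyl to phenyl. Within the data shown here, no measured step removes a halogen outright, so the only guidance is that the single related halogen swap stayed modest. A small shift in either direction, or none beyond the scatter, is therefore expected in this assay. The expected step is a 1.2-fold lower number from compound 3 to compound 4 (0.08 log units; within the scatter). Compound 4 is expected to give 30000 nM, with a range from 12000 nM to 75000 nM.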

Compound 4, half-maximal cytotoxic concentration: 39000 nM
For compound 4 the middle estimate is 1.3-fold (0.11 log units) below the measured one; measured number inside the range.
By their numbers in this assay, from the lowest: compound 2; then compounds 1, 3 and 4 (each within the scatter of the next).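

In this assay the change from 2-bromophenyl to phenyl gives a 1.1-fold higher number from compound 3 to compound 4 (0.03 log units; within the scatter) and so the bromo group at this place, ortho to a large group, leaves no mark that can be told from the usual scatter. Set against the same plain phenyl, the 4-iodophenyl of the earlier series gives a 3.9-fold higher number from compound 2 to compound 4 (0.59 log units; beyond the scatter) while the methoxy group gives a 1.5-fold higher number from compound 1 to compound 4 (0.18 log units; within the scatter) and so, of these three groups, only iodo comes with a step beyond the scatter. No separate measurement is at hand to explain these numbers.

The compounds shown leave open whether an amine or a carboxylic acid at this same place would shift the number. They also leave open whether iodo would give the same step if it sat where the bromo group sits in compound 3.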